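Isopropyl for methyl on the anilino ring of compound 2

This account rests on a few compounds, and the source may have more. Where it says the series, first, only, none or still open, it means among the compounds named here.

Compound 1 `COc1cc(/C=C/c2nc(N3CCN(C)CC3)c3sccc3n2)cc(OC)c1OC`: only a limit, > 1000000 nM
Compound 2 `COc1cc(/C=C/c2nc(Nc3ccc(C)cc3)c3sccc3n2)cc(OC)c1OC`: only a limit, < 40000 nM

In a functional assay on L02 cells (Homo sapiens) for inhibition, read by Griess assay, with stated times of 1 h and 24 h (a higher number here means a weaker inhibitor, a lower number a stronger inhibitor), compound 1 gives only a limit, > 1000000 nM. Compound 2 in this assay likewise gives only a limit, < 40000 nM. Between them lies an at least 25-fold lower number from compound 1 to compound 2 (1.39 log units; beyond the scatter), a change at the carbon bearing the amine; both ends of this step rest on limits the limit of < 40000 nM in this assay, at which 1 of the 2 values shown sits (the limit of > 1000000 nM in this assay, at which 1 of the 2 values shown sits), so its true size is known only as a minimum. Compound 3 `COc1cc(/C=C/c2nc(Nc3ccc(C(C)C)cc3)c3sccc3n2)cc(OC)c1OC` has not been measured in this assay. It differs from compound 2 by isopropyl in place of methyl on an aromatic carbon. For the measured compounds named here, no measured step touches this ring: the single step known lies at another place, and its size cannot guide a change of methyl to isopropyl. The expectation for compound 3 is therefore no step beyond the scatter, a step that the limit leaves unreadable from compound 2 to compound 3. Compound 3 is thus estimated at 20000 nM, within 5000 nM to 60000 nM. Compound 2 is known only as a limit, and a limit for compound 3 is also possible.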

Compound 3, half-maximal inhibitory concentration: 370000 nM
For compound 3 the middle estimate is 19-fold (1.27 log units) below the measured one; measured number outside the range, above it.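

In this assay, the aromatic carbon that the earlier step left untouched proves sensitive to a change that adds only carbon, with isopropyl in place of methyl giving an at least 9.2-fold higher number from compound 2 to compound 3 (0.96 log units; beyond the scatter). This step is known only as a minimum, because compound 2 stands at a limit: the limit of < 40000 nM in this assay, at which 1 of the 3 values shown sits. The (4-isopropylphenyl)amino group in place of 4-methylpiperazin-1-yl still gives an at least 2.7-fold lower number from compound 1 to compound 3 (0.43 log units; beyond the scatter), again only a minimum, because the starting end of this step is a limit: the limit of > 1000000 nM in this assay, at which 1 of the 3 values shown sits.

The compounds shown carry only methyl and isopropyl on this ring, so they do not tell how ethyl, methoxy or a carboxylic acid on the same carbon would read. As far as these compounds go, with compound 2 known only as a limit, the true size of the change from methyl to isopropyl also stays open.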